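A few compounds are considered here, and "the series" means these few. Any claim that something is new, unique, unknown or untested is made for them only; others in the source may bear on it.

Working notes on the amide series. The shared core carries a two-carbon link from a saturated chain carbon to an amide carbonyl, and the three measured compounds differ only in what sits on the amide nitrogen. Compound 1 `CCCNC(=O)CC1CCc2cc(OC)c(OC)cc21` gives 22.2% in a functional assay on the whole organism (strain Wistar) for inhibition, with Rattus norvegicus as the target, read by paw edema, with stated times of 60 min and 6 h, at a dose of 100 mg/kg by the oral route; a lower number here means less inhibition, a higher number more inhibition at the dose given (going by the name of the read-out). Compound 2 `CCCCNC(=O)CC1CCc2cc(OC)c(OC)cc21` gives 24.1% in this assay, and compound 3 `COc1cc2c(cc1OC)C(CC(=O)NC(C)(C)C)CC2` gives 31.5% in this assay. Compound 1 stands at the lowest of the three numbers, but every step from it lies within the scatter: a number 1.9 percentage points higher from compound 1 to compound 2 (within the scatter) and a number 9.3 percentage points higher from compound 1 to compound 3 (within the scatter). The remaining step, a number 7.4 percentage points higher from compound 2 to compound 3 (within the scatter), is also within the scatter.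

Compound 4 `COc1cc2c(cc1OC)C(CC(=O)N1CCOCC1)CC2` is not yet measured in this assay. It differs from compound 1 in one place: morpholin-4-yl in place of propylamino on a carbonyl carbon. Going by the values given here, none of the measured steps bears closely on this change; they replace one alkyl group by another on the amide nitrogen, whereas here the amide hydrogen is lost and a six-membered ring with two hetero atoms enters. Among the compounds with values here, the only guidance is that three variations at this site gave no step beyond the scatter, so no step beyond the scatter is expected in this assay for compound 4 either, with the range kept wide for want of a matching precedent. Compound 4 is therefore estimated at 24%, within 10% to 38%, an expected step of a number 1.8 percentage points higher from compound 1 to compound 4 (within the scatter).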

Compound 4, a percentage reported as inhibition, in the whole organism at one dose (the size of the read-out at that dose, not a potency): 14.8%
For compound 4 the middle estimate is 9.2 percentage points above the measured one, within the range that was stated.
By their numbers in this assay, from the lowest: compounds 4, 1, 2 and 3 (each within the scatter of the next, the first and the last beyond it).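

Morpholin-4-yl on the carbonyl carbon gives the first step at this position that lies beyond the scatter in this assay, with a number 16.7 percentage points lower from compound 3 to compound 4 (beyond the scatter) as (tert-butyl)amino leaves; the earlier compounds, which all keep the amide hydrogen and an open chain, showed no such step among themselves. The finding is limited to that one pair, as the same change stays inside the scatter against the two straight-chain amides, with a number 7.4 percentage points lower from compound 1 to compound 4 (within the scatter) and with a number 9.3 percentage points lower from compound 2 to compound 4 (within the scatter) as the readings there, so it cannot be called a general effect of replacing an alkylamino group at this position. No measurement at hand accounts for the step.

The compounds shown leave open which part of the change matters: the loss of the amide hydrogen, the six-membered ring or its oxygen, all of which enter or leave together in compound 4. A piperidin-1-yl group or a dimethylamino group on the same carbonyl carbon would pull these apart, the first keeping the ring without the oxygen and the second losing the amide hydrogen without any ring.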